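Adding a Phenyl Group to a Lactam Ring

The compounds below may be only part of what the source reports. "The series", "measured", "known", "first", "only" and "open" are said of these compounds alone.

Measured compounds:
compound 1 `O=C(CCCCC[C@H](NC(=O)[C@@H]1CCCC(=O)N1)C(=O)Nc1ccccc1)NO` gives 47 nM
compound 2 `O=C(CCCCC[C@H](NC(=O)C1CCNC1=O)C(=O)Nc1ccccc1)NO` gives 150 nM

Both compounds were tested in an assay on isolated protein for inhibition of histone deacetylase 11 (Homo sapiens), read by fluorescence; a higher number here means a weaker inhibitor, a lower number a stronger inhibitor. Compound 2 stands at the higher of the two numbers, the weaker inhibitor of the pair, with compound 1 reached by the step of a 3.2-fold higher number from compound 1 to compound 2 (0.50 log units; beyond the scatter), a change of ring in the lactam attached to the carbonyl carbon.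

Compound 3 `O=C(CCCCC[C@H](NC(=O)C1C(=O)NCC1c1ccccc1)C(=O)Nc1ccccc1)NO` keeps the five-membered lactam of compound 2 and differs from it by phenyl in place of hydrogen on a saturated ring carbon, on a saturated ring carbon of a five-membered non-aromatic ring with one nitrogen, two ring bonds from the ring nitrogen. Within the data shown here, no measured step shows what a phenyl group in this position does: the only step on record changes the ring size, not a substituent on the ring, so it offers no guide to this change. With nothing in the data pointing either way, the expectation is a step of a 1.2-fold lower number from compound 2 to compound 3 (0.06 log units; within the scatter) that stays within the usual scatter. Compound 3 is therefore estimated at 130 nM, with a range from 40 nM to 400 nM.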

Compound 3, half-maximal inhibitory concentration: 70 nM
The estimate for compound 3 lay 1.9-fold (0.27 log units) above the measured number; the measured number falls inside the stated range.
By their numbers in this assay, from the lowest: compounds 1 and 3 (each within the scatter of the next); then compound 2.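

In this assay, putting phenyl in place of hydrogen on a saturated ring carbon of the five-membered lactam, two ring bonds from the ring nitrogen, gives a 2.1-fold lower number from compound 2 to compound 3 (0.33 log units; beyond the scatter) and so makes a modestly stronger inhibitor. Among these compounds, the only earlier step changed the size of the lactam ring, whereas this one shows that a substituent of six carbon atoms on the ring is compatible with inhibition at this carbon and that the number moves in the favorable direction. No measurement on hand explains the shift, so the reason for it remains unknown.

From the compounds shown here alone, it remains open whether the gain belongs to phenyl itself or would also appear with a methyl group, a cyclohexyl ring, or a phenyl carrying an amine or a carboxylic acid. Among the compounds shown here, it is also unclear whether phenyl on the 6-oxopiperidin-2-yl ring of compound 1 would shift the number in the same direction, since the one step here was taken on the five-membered lactam alone.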